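Swapping methylamino for methylsulfanyl on a shared core

The compounds below may be only part of what the source reports. "The series", "measured", "known", "first", "only" and "open" are said of these compounds alone.

Three compounds with the same core differ only in one group on an aromatic carbon. In a functional assay on cells (Homo sapiens), read by thymidine incorporation (on this read-out higher numbers stand for weaker inhibition and lower numbers for stronger inhibition), compound 1 `CC(O)c1cc(NCc2cccnc2)n2ncc(Br)c2n1` gives 1400 nM, compound 2 `CCOC(=O)c1cc(NCc2cccnc2)n2ncc(Br)c2n1` gives 2900 nM, and compound 3 `CNc1cc(NCc2cccnc2)n2ncc(Br)c2n1` gives 1200 nM. Compound 3 is level with one neighbour and modestly ahead of the other, as a 1.2-fold lower number from compound 1 to compound 3 (0.07 log units; within the scatter) and a 2.4-fold lower number from compound 2 to compound 3 (0.38 log units; beyond the scatter) show.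

Compound 4 `CSc1cc(NCc2cccnc2)n2ncc(Br)c2n1` has methylsulfanyl in place of methylamino on an aromatic carbon. For the measured compounds named here, no measured step makes this exact swap, so the evidence is indirect. Exchanging ethoxycarbonyl for 1-hydroxyethyl at this carbon gave only a 2.1-fold higher number from compound 1 to compound 2 (0.32 log units; beyond the scatter), and the largest step seen so far is a 2.4-fold lower number from compound 2 to compound 3 (0.38 log units; beyond the scatter). With such small shifts among these three groups, a large move is not expected here. The step expected in this assay is a 1.3-fold higher number from compound 3 to compound 4 (0.10 log units; within the scatter), which means none beyond the scatter. For compound 4 the estimated value is 1500 nM, with an expected range from 700 nM to 3200 nM.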

Compound 4, half-maximal inhibitory concentration: 990 nM
Compound 4: the middle estimate sits 1.5-fold (0.18 log units) above what was measured, within the range that was stated.
By their numbers in this assay, from the lowest: compounds 4, 3 and 1 (each within the scatter of the next); then compound 2.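

In this assay, methylsulfanyl and methylamino on this aromatic carbon cannot be told apart (a gap of a 1.2-fold lower number from compound 3 to compound 4 (0.08 log units; within the scatter)), even though the entering group has 0 hydrogen-bond donors and the leaving group has 1. Methylsulfanyl is also level with 1-hydroxyethyl (a 1.4-fold lower number from compound 1 to compound 4 (0.15 log units; within the scatter)), whereas ethoxycarbonyl remains apart (a 2.9-fold lower number from compound 2 to compound 4 (0.47 log units; beyond the scatter)), which is the widest gap among these four compounds but still a modest one. No measurement at hand accounts for how these groups compare.

The compounds shown leave open whether a longer chain on this carbon, such as ethylsulfanyl or butylamino, would keep the number at this level. They also do not tell how a carboxylic acid, a dimethylamino group or a plain hydrogen at the same place would compare.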